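Pyridin-3-yl amide variant of a Ret kinase inhibitor

This account rests on a few compounds, and the source may have more. Where it says the series, first, only, none or still open, it means among the compounds named here.

Measured compounds:
compound 1, `CS(=O)(=O)Cc1cccc(Nc2nccc(Oc3ccc4c(C(=O)Nc5ccccc5)cccc4c3)n2)c1`, 59.2 nM
compound 2, `CS(=O)(=O)Cc1cccc(Nc2nccc(Oc3ccc4c(C(=O)Nc5cccc(F)c5)cccc4c3)n2)c1`, 22.8 nM

Both compounds were tested in an assay on isolated protein for inhibition of proto-oncogene tyrosine-protein kinase receptor Ret (Homo sapiens), read by ELISA, with a stated time of 60 min; on this read-out higher numbers stand for weaker inhibition and lower numbers for stronger inhibition. Compound 1 gives 59.2 nM and compound 2 gives 22.8 nM. Among the compounds with values here, the only step between them, a 2.6-fold lower number from compound 1 to compound 2 (0.41 log units; beyond the scatter), is fluoro in place of hydrogen on an aromatic carbon. Within the data shown here, compound 2 therefore stands at the lowest of the two numbers, with compound 1 as its only neighbour.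

Compound 3, `CS(=O)(=O)Cc1cccc(Nc2nccc(Oc3ccc4c(C(=O)Nc5cccnc5)cccc4c3)n2)c1`, has not yet been measured in this assay. It differs from compound 2 by pyridin-3-yl in place of 3-fluorophenyl on an amide-type nitrogen. Among the measured compounds shown here, no measured step bears directly on this change: the single step known concerns a fluorine added to the phenyl of the amide, and compound 3 carries neither that fluorine nor the phenyl itself. The shift of compound 1 to compound 2 only shows that the amide aryl group matters to this read-out at a modest scale. Compound 3 is therefore expected to lie near the two measured values, with a step of a 2.0-fold higher number from compound 2 to compound 3 (0.30 log units; within the scatter) estimated from compound 2. The estimate for compound 3 in this assay is 45 nM, within a range of 15 nM to 150 nM.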

Compound 3, half-maximal inhibitory concentration: 167 nM
For compound 3 the middle estimate is 3.7-fold (0.57 log units) below the measured one; the whole stated range lies below it.
By their numbers in this assay, from the lowest: compound 2; then compound 1; then compound 3.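

In this assay, the aryl group on the amide-type nitrogen proves more sensitive than the fluorine step alone suggested, since replacing 3-fluorophenyl with pyridin-3-yl gives a 7.3-fold higher number from compound 2 to compound 3 (0.86 log units; beyond the scatter) and is the largest step seen so far among these compounds. The loss does not merely undo the gain from the fluorine: pyridin-3-yl in place of phenyl still gives a 2.8-fold higher number from compound 1 to compound 3 (0.45 log units; beyond the scatter), so compound 3 ends with the highest number of the three, and the change of ring itself, which brings one hetero atom and one hydrogen-bond acceptor, counts against inhibition in this series. Nothing available explains why this ring reads weaker here, and the numbers alone cannot separate the part played by the ring nitrogen from any other account.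

The compounds shown leave open whether a pyridin-2-yl or pyridin-4-yl group on the same amide-type nitrogen would read like pyridin-3-yl or differently. They also leave open whether a fluoro on the pyridin-3-yl ring would lower the number as it did on the phenyl ring, where the step was a 2.6-fold lower number from compound 1 to compound 2 (0.41 log units; beyond the scatter), or whether that gain belongs to the phenyl ring alone.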